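The compounds below may be only part of what the source reports. "The series", "measured", "known", "first", "only" and "open" are said of these compounds alone.

Working notes on the series, read in a functional assay on KB 3-1 cells (Homo sapiens) for cytotoxicity, read by MTT assay, with a stated time of 68 h; a lower number here means a stronger inhibitor, a higher number a weaker inhibitor. Compound 1 `COc1ccc(-c2cc(NC(=O)C(Cl)Cl)cc(-c3ccc(OC)cc3)c2)cc1` gives > 30000 nM as a limit of the assay. Compound 2 `COc1ccc(-c2cccc(NC(=O)C(Cl)Cl)c2)cc1` gives > 50000 nM and this too is a limit. Compound 3 `O=C(Nc1cccc(-c2cccc(NC(=O)C(Cl)Cl)c2)c1)C(Cl)Cl` gives > 50000 nM as a limit as well. No value in the series is a number: the readings consist of the limit of > 30000 nM in this assay, at which 1 of the 3 values shown sits, and the limit of > 50000 nM in this assay, at which 2 of the 3 values shown sit, alone.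

Compound 4 `COC(=O)c1ccc(-c2cccc(NC(=O)C(Cl)Cl)c2)cc1` carries methoxycarbonyl in place of methoxy on an aromatic carbon, para to a large group (methoxycarbonyl in place of methoxy on an aromatic carbon). For the measured compounds named here, the only measured step is a step that the two limits leave unreadable from compound 1 to compound 2 and it offers no size to carry over. The anchor for compound 4 is therefore compound 2 at > 50000 nM and that reading remains a limit. No change beyond the scatter is expected in this assay and the expected step is a number no higher from compound 2 to compound 4 (the limit leaves the size open) on that basis. For compound 4 the estimate is 50000 nM with an expected range from 15000 nM to 100000 nM and a reading at a limit is the likeliest outcome.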

Compound 4, half-maximal inhibitory concentration: > 50000 nM
Compound 4: no number, only a limit; the forecaster's own chance of this, stated with the estimate: 75%; the middle value sits exactly at the limit.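

No step can be read from compound 2 to compound 4, since both readings are limits of the assay and not numbers: the limit of > 50000 nM in this assay, at which 3 of the 4 values shown sit.

The compounds shown leave open how methoxycarbonyl and methoxy compare, and whether any change to the shared core gives a numerical reading.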